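The compounds below may be only part of what the source reports. "The series", "measured", "known", "first", "only" and "open" are said of these compounds alone.

The measured compounds, read in a functional assay on NCI-H1299 cells (Homo sapiens) for inhibition, read by scintillation counting, with a stated time of 30 min, tested at 30 uM; a lower number here means less inhibition, a higher number more inhibition at the concentration tested (going by the name of the read-out):

Compound 1, `O=C(Oc1cccc(F)c1OC(=O)c1cc(O)c(O)c(O)c1)c1cc(O)c(O)c(O)c1`, gives 81.1%.
Compound 2, `COc1cccc(OC(=O)c2cc(O)cc(O)c2)c1OC(=O)c1cc(O)cc(O)c1`, gives 69.4%.
Compound 3, `O=C(Oc1ccc(Cl)cc1OC(=O)c1ccc(O)c(O)c1)c1ccc(O)c(O)c1`, gives 94.4%.

Among these three, compound 2 stands lowest in this assay. Its nearest neighbour is compound 1, whose number lies higher by more than the usual scatter, and compound 3 lies higher still, again beyond the scatter. Among the measured compounds shown here, no two of the measured compounds differ in only one place, so no single step has been measured, and the three values are all that is known.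

Compound 4, `O=C(Oc1cccc(OC(=O)c2cc(O)cc(O)c2)c1OC(=O)c1cc(O)cc(O)c1)c1cc(O)cc(O)c1`, has not yet been tested. It differs from compound 2 in one place: (3,5-dihydroxyphenyl)carbonyl in place of methyl on an oxygen on an aromatic ring. The change brings a third ester of the kind already present twice in compound 2, with further hydroxyl groups on the new ring.

The compounds carrying more phenolic esters sit higher here, compound 1 at 81.1% and compound 3 at 94.4%. On that basis the step of a number 7.6 percentage points higher from compound 2 to compound 4 (within the scatter) is expected to be a modest rise, probably not far beyond the scatter. Compound 4 is therefore expected to give about 77%, between 62% and 90%.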

Compound 4, a percentage reported as inhibition, at one concentration (the size of the read-out at that concentration, not a potency): 98.7%
Compound 4: the middle estimate sits 21.7 percentage points below what was measured, and the stated range ends below it.
By their numbers in this assay, from the lowest: compound 2; then compound 1; then compounds 3 and 4 (each within the scatter of the next).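

In this assay, among the compounds shown here, the change from methoxy to ((3,5-dihydroxyphenyl)carbonyl)oxy on an aromatic ring gives a number 29.3 percentage points higher from compound 2 to compound 4 (beyond the scatter) and provides the first single-place comparison. The earlier compounds shown here could not isolate any one change, whereas this pair shows that the read-out responds to what is carried on this oxygen. The finding applies to this pair alone, and no measurement shown accounts for the size of the step.

The compounds shown leave open whether the whole (3,5-dihydroxyphenyl)carbonyl group is needed or whether a plain benzoyl or acetyl group on the same oxygen would give a similar number. They also leave open how an amine or a carboxylic acid carried at this place would read.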